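Changing the amide nitrogen substituent in a methylsulfonyl series

This account rests on a few compounds, and the source may have more. Where it says the series, first, only, none or still open, it means among the compounds named here.

Compound 3 `CS(=O)(=O)c1c(CCc2ccccc2)c2cc(OCC(=O)Nc3ccccc3)ccc2[nH]c1=O` stands at a limit in an assay on CHO cells for displacement of a labelled ligand from adenosine receptor A2b (Homo sapiens), read by scintillation counting, with a stated time of 60 min (a lower number here means a stronger inhibitor, a higher number a weaker inhibitor), namely > 10000 nM. Compound 2 `CS(=O)(=O)c1c(CCc2ccccc2)c2cc(OCC(=O)NCC3CC3)ccc2[nH]c1=O` likewise gives only a limit in this assay, > 10000 nM. The step that the two limits leave unreadable from compound 2 to compound 3 cannot be read, since both values sit at the limit of > 10000 nM in this assay, at which 2 of the 3 values shown sit. Compound 1 `O=C(COc1ccc2[nH]c(=O)c(-c3nccs3)c(CCc3ccccc3)c2c1)NC1(c2ccccc2)CC1`, which differs from these in several places, gives 12 nM in this assay. Compound 4 `CN(Cc1ccc(Cl)c(Cl)c1)C(=O)COc1ccc2[nH]c(=O)c(S(C)(=O)=O)c(CCc3ccccc3)c2c1` arises from compound 3 by (3,4-dichlorobenzyl)(methyl)amino in place of anilino on a carbonyl carbon. For the measured compounds named here, the one measured step that changes the same amide nitrogen is unreadable, so no size of step can be drawn from it. Compound 4 is expected to remain near the limit, estimated at 10000 nM within a range of 3000 nM to 30000 nM. The expected step of a number no higher from compound 3 to compound 4 (the limit leaves the size open) is thus none beyond the scatter.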

Compound 4, inhibition constant: 710 nM
For compound 4 the middle estimate is 14-fold (1.15 log units) above the measured one, and the stated range ends above it.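

In this assay, the group on the carbonyl carbon turns out to matter in this methylsulfonyl series, which the earlier pair could not show, since the step between compounds 2 and 3 cannot be read. Placing (3,4-dichlorobenzyl)(methyl)amino there in place of anilino gives an at least 14-fold lower number from compound 3 to compound 4 (1.14 log units; beyond the scatter). Placing it there in place of (cyclopropylmethyl)amino gives an at least 14-fold lower number from compound 2 to compound 4 (1.14 log units; beyond the scatter).

Going by these compounds, the change alters several things at once, so the part responsible remains open. Plain benzylamino, (benzyl)(methyl)amino without the chlorines, or (3,4-dichlorobenzyl)amino without the methyl would separate these contributions.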